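This account rests on a few compounds, and the source may have more. Where it says the series, first, only, none or still open, it means among the compounds named here.

Compound 1 `Cc1ccc(S(=O)(=O)N(CC(=O)NCc2ccc(Cl)cc2)c2ccccn2)cc1`: in a functional assay on CHO-K1 cells for antagonist activity at prostaglandin E2 receptor EP1 subtype (Homo sapiens), read by FLIPR and calcium flux (a higher number here means a weaker inhibitor, a lower number a stronger inhibitor), compound 1 gives < 1450 nM, which is a limit of the assay rather than a number.
Compound 2 `Cc1ccc(S(=O)(=O)N(CC(=O)NCc2ccc(Cl)cc2)c2cccnc2C)cc1`: in this assay compound 2 gives 676 nM.
Compound 3 `Cc1ccc(S(=O)(=O)N(CC(=O)NCc2ccc(Cl)cc2)c2ccc(C)cn2)cc1`: in this assay compound 3 gives < 1450 nM, again a limit.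

Going by the values given here, compound 3 therefore stands only at the limit of < 1450 nM in this assay, at which 2 of the 3 values shown sit, with no exact number of its own; compound 2 is the single compound with a measured value. Compound 4 `Cc1ccc(S(=O)(=O)N(CC(=O)NCc2ccc(Cl)cc2)c2ccnn2C)cc1` carries the change (1-methyl-1H-pyrazol-5-yl in place of 5-methylpyridin-2-yl on a sulfonamide nitrogen). Among the compounds with values here, the measured steps a step that the limit leaves unreadable from compound 1 to compound 2, a step that the two limits leave unreadable from compound 1 to compound 3 and a step that the limit leaves unreadable from compound 2 to compound 3 cannot be read in size, so no step gives guidance on this change, and the expectation rests on the values themselves. Compound 4 is expected near 900 nM, within 300 nM to 2700 nM, with a fair chance that only a limit is reported. The expected step is a step that the limit leaves unreadable from compound 3 to compound 4.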

Compound 4, inhibition constant: 589 nM
Beside the measured number, compound 4's estimate is 1.5-fold (0.18 log units) above it, and the stated range covers the measured number.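

Compound 4 gives this position on the sulfonamide nitrogen a second exact reading, and 1-methyl-1H-pyrazol-5-yl in place of 2-methylpyridin-3-yl is a 1.1-fold lower number from compound 2 to compound 4 (0.06 log units; within the scatter). In this pair, a five-membered aromatic ring with 2 hetero atoms therefore reads the same as a six-membered one with 1 hetero atom. The steps to compound 4 from compound 1 and compound 3 cannot be read, because those two compounds have only a limit: the limit of < 1450 nM in this assay, at which 2 of the 4 values shown sit.

The compounds shown leave open how a non-aromatic group, such as piperidin-4-yl, would read on this nitrogen. They also leave open whether the methyl on the pyrazole matters.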